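A few compounds are considered here, and "the series" means these few. Any claim that something is new, unique, unknown or untested is made for them only; others in the source may bear on it.

Compound 1 `COC(=O)c1c(Nc2ccccc2)sc(C(=O)c2ccc(OC)cc2)c1C`: 48.1%
Compound 2 `COC(=O)c1c(Nc2ccc(C)cc2)sc(C(=O)c2ccc(OC)cc2)c1C`: "not active" (no number reported)
Compound 3 `COC(=O)c1c(Nc2ccccc2)sc(C(=O)c2ccc(C)cc2)c1C`: 9.35%

All three share one core and were tested in a functional assay, with a stated time of 150 min, tested at 30 ug/mL; a higher number here means a stronger effect of the compound at the concentration tested, a lower number a weaker effect. Compound 3 stands lowest of the two compounds that gave a number; the nearest, compound 1, gives 48.1%, and the step of a number 38.8 percentage points lower from compound 1 to compound 3 (beyond the scatter) is large. Compound 4 `COC(=O)c1c(Nc2ccc(C)cc2)sc(C(=O)c2ccc(C)cc2)c1C` has not yet been measured. It differs from compound 3 by methyl in place of hydrogen on an aromatic carbon. Going by the values given here, no measured step with numbers on both sides covers this change. The same change does appear between compound 1 and compound 2: compound 1 gives 48.1%, while compound 2 is reported as "not active" (no number reported). The expectation is therefore a step of a number 6.4 percentage points lower from compound 3 to compound 4 (within the scatter) downward, or none beyond the scatter, from an already low starting point. Compound 4 is estimated at 3%, between 0% and 12%, with a real chance that it is simply reported as not active.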

Compound 4, a percentage reported as activity, at one concentration (the size of the read-out at that concentration, not a potency): "not active" (no number reported)
Compound 4: no number reported; no gap can be computed for the estimate.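

Going by these compounds alone, compound 4 carries no number, so no step from compound 3 to compound 4 can be read, and no evidence here bears on this result. The compounds shown leave open whether compound 4 retains any small effect.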